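This account rests on a few compounds, and the source may have more. Where it says the series, first, only, none or still open, it means among the compounds named here.

Measured so far:
compound 1, `CC(C)n1ncc2c(C(=O)Nc3cccnc3)cccc21`: > 40000 nM
compound 2, `Cc1ccc(-n2cc(CNC(=O)c3cccc4c3cnn4C(C)C)nn2)c(C)c1`: 10600 nM

Within the data shown here, in a functional assay on PC-3 cells (Homo sapiens) for inhibition, read by MTT assay, with a stated time of 72 h (on this read-out higher numbers stand for weaker inhibition and lower numbers for stronger inhibition), compound 2 gives 10600 nM, the only actual number in this small set. Compound 1 gives > 40000 nM in this assay, which is a limit of the assay and not a number; see (the limit of > 40000 nM in this assay, at which 1 of the 2 values shown sits). Compound 3, `CC(C)n1ncc2c(C(=O)NCc3cn(-c4cccc(Br)c4)nn3)cccc21`, differs from compound 2 by 3-bromophenyl in place of 2,4-dimethylphenyl on an aromatic nitrogen. Among the measured compounds shown here, no step between measured compounds is available to size this kind of change, so no shift beyond the usual scatter in this assay is expected in either direction. For compound 3 the estimate is 12000 nM, within 4000 nM to 40000 nM. That expectation corresponds to a step of a 1.1-fold higher number from compound 2 to compound 3 (0.05 log units; within the scatter).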

Compound 3, half-maximal inhibitory concentration: 33700 nM
Beside the measured number, compound 3's estimate is 2.8-fold (0.45 log units) below it, within the range that was stated.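

Aryl choice on the aromatic nitrogen is not neutral in this assay: 3-bromophenyl in place of 2,4-dimethylphenyl gives a 3.2-fold higher number from compound 2 to compound 3 (0.50 log units; beyond the scatter). This single pair cannot separate the effect of adding the bromine from that of losing the 2,4-dimethyl pattern. Compound 3 leaves little room for sizing further losses in this series: the limit of > 40000 nM in this assay, at which 1 of the 3 values shown sits.

Still open, going by these compounds, is whether unsubstituted phenyl, or a phenyl ring carrying an amine or a carboxylic acid, would restore inhibition at this position. On these data alone, whether a non-aromatic group such as cyclohexyl is tolerated there is also open.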